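Bromo for chloro on a second indole-thioether core

The source may report more compounds than this note shows. Statements on the series, on what has been measured and on what is new or still open speak of the compounds shown alone.

Measured compounds:
Compound 1, `Cc1[nH]c2ccc(Cl)cc2c1SC1CCNCC1`, gives 0.8 mg/kg in a functional assay on the whole organism with Mus musculus as the target, in the writhing test; a higher number here means that more compound is needed for the effect, a lower number that less compound is needed.
Compound 2, `Cc1[nH]c2ccc(Br)cc2c1SC1CCNCC1`, gives 0.7 mg/kg in this assay.
Compound 3, `CON1CCC(Sc2c[nH]c3ccc(Cl)cc23)CC1`, gives 1.4 mg/kg in this assay.

Compound 1 and compound 2 differ in one place only, (bromo in place of chloro on an aromatic carbon). The step of a 1.1-fold lower number from compound 1 to compound 2 (0.06 log units; within the scatter), so within the pair the exchange of halogen leaves the dose essentially unchanged. Compound 3 carries a different core; the difference between the core of compound 3 and the core of compound 1 is not broken down here. Its value lies within the scatter of the values of both compound 1 and compound 2, so no ordering among the three measured compounds can be read from these numbers.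

Compound 4, `CON1CCC(Sc2c[nH]c3ccc(Br)cc23)CC1`, has not been measured. It differs from compound 3 in one place, (bromo in place of chloro on an aromatic carbon). This is the same change that separates compound 1 from compound 2, made at the same place on the aromatic ring. Among the compounds with values here, the one measured instance of this change, the step of a 1.1-fold lower number from compound 1 to compound 2 (0.06 log units; within the scatter), gives the only basis for an expectation, and it suggests a step of similar size, that is, no meaningful movement, from compound 3 to compound 4.

Compound 4 is therefore expected to show a step of a 1.1-fold lower number from compound 3 to compound 4 (0.03 log units; within the scatter), giving an estimated 1.3 mg/kg, with the likely range running from 0.6 mg/kg to 2.8 mg/kg.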

Compound 4, dose for half-maximal effect: 1.6 mg/kg
Compound 4: middle estimate off by 1.2-fold (0.09 log units), on the low side; the measured number falls inside the stated range.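

In this assay, the exchange of chloro for bromo on the aromatic carbon gives a 1.1-fold higher number from compound 3 to compound 4 (0.06 log units; within the scatter), and set beside the earlier instance of the same change, the result on the two cores agrees: the same change on two cores in this assay, a 1.1-fold lower number (0.06 log units; within the scatter) from compound 1 to compound 2 and a 1.1-fold higher number (0.06 log units; within the scatter) from compound 3 to compound 4, 1.3-fold (0.12 log units) apart, within the scatter of two such steps On the core of compound 1 and the core of compound 3 alike, then, this halogen exchange leaves the dose within the usual scatter, and the opposite directions of the two steps carry no meaning. This shows that a silent exchange stayed silent on a second core, but it rests on two pairs only, so it does not establish that the same would hold on any further core, and, since neither step produced a real shift, it does not show that a change with a real effect on one of these cores would carry over to the other.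

The compounds shown leave open whether anything other than these two halogens can be placed on this aromatic carbon without shifting the dose, for instance fluoro, methoxy, a nitrile or trifluoromethyl. They also leave open what the compound with hydrogen at this place would give, and so whether a halogen is needed there at all.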